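A few compounds are considered here, and "the series" means these few. Any claim that something is new, unique, unknown or untested is made for them only; others in the source may bear on it.

Among the compounds with values here, in a physicochemical assay for lipophilicity, at pH 7.4 (a higher number here means a more lipophilic compound, a lower number a more polar compound), compound 2 (`Cc1cc(NC(=O)OCC(C)C)nn1Cc1cc(Cl)ccc1OCc1ccccc1`) gives 3.3, the only actual number so far. Compound 1 (`Cc1cc(C(=O)Nc2ccccn2)nn1Cc1cc(Cl)ccc1OCc1ccccc1`) gives > 3.7, which is a limit of the assay and not a number. Within the data shown here, the one measured step, a number at least 0.40 log units lower from compound 1 to compound 2 (beyond the scatter), put (isobutoxycarbonyl)amino in place of (pyridin-2-yl)carbamoyl on an aromatic carbon. It concerns a different change, so it offers only a rough guide to size.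

Compound 3 (`Cc1cc(NC(=O)O[C@H]2CCOC2)nn1Cc1cc(Cl)ccc1OCc1ccccc1`) differs from compound 2 in one place: oxolan-3-yl in place of isobutyl on an oxygen next to a carbonyl group. Oxolan-3-yl stands in place of isobutyl on an oxygen next to a carbonyl group, and it carries a hydrogen-bond acceptor. Among the measured compounds shown here, no measured step tests this exchange directly. Starting from compound 2 at 3.3, a fall beyond the scatter in this assay is expected with that entering acceptor. The estimated step is a number 0.80 log units lower from compound 2 to compound 3 (beyond the scatter). For compound 3 the expected value is 2.5, with an estimated range from 2.1 to 2.9.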

Compound 3, distribution coefficient: 2.7
Compound 3: the middle estimate sits 0.20 log units below what was measured; the range from low to high includes it.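

On an oxygen next to a carbonyl group, oxolan-3-yl in place of isobutyl gives a number 0.60 log units lower from compound 2 to compound 3 (beyond the scatter) in this assay. Within the data shown here, this is the first step here with a number at both ends, and it shows that the group on this oxygen can shift the read-out beyond the scatter. The wider exchange, (((oxolan-3-yl)oxy)carbonyl)amino in place of (pyridin-2-yl)carbamoyl on an aromatic carbon, gives a number at least 1.00 log units lower from compound 1 to compound 3 (beyond the scatter), and its full size stays open, as its starting point is a limit of the assay and not a number: the limit of > 3.7 in this assay, at which 1 of the 3 values shown sits.

The compounds shown leave open how much of the step belongs to the ring and how much to its oxygen, and whether the defined stereocentre plays any part. Cyclopentyl or 2-methoxyethyl on the same oxygen would bear on the first question, and the opposite form of oxolan-3-yl on the second.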